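Working notes: trifluoromethoxy swap on the aryl ether

The source may hold more compounds than are shown below. What is called first, only, known or untested is meant among the compounds shown, and "the series" means these compounds.

- Compound 1 `CC(O)(COc1ccc(S(F)(F)(F)(F)F)cc1)C(=O)Nc1cccc(S(F)(F)(F)(F)F)c1`: 8000 nM
- Compound 2 `CC(O)(COc1ccc(C(F)(F)F)cc1)C(=O)Nc1cccc(S(F)(F)(F)(F)F)c1`: 13300 nM

In a functional assay on VCaP cells (Homo sapiens) for antiproliferative activity, read by propidium iodide staining, with a stated time of 96 h (on this read-out higher numbers stand for weaker inhibition and lower numbers for stronger inhibition), compound 2 gives 13300 nM. Among the measured compounds shown here, that is the higher of only two numbers, but it lies within the scatter of compound 1 at 8000 nM, so the two cannot be ranked.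

Compound 3 `CC(O)(COc1ccc(OC(F)(F)F)cc1)C(=O)Nc1cccc(S(F)(F)(F)(F)F)c1` has not yet been measured. The change from compound 2 is trifluoromethoxy in place of trifluoromethyl on an aromatic carbon, para to a large group.

For the measured compounds named here, one measured step bears on this: a 1.7-fold higher number from compound 1 to compound 2 (0.22 log units; within the scatter). It is also a swap of one group on an aromatic carbon, and it stayed within the scatter. Going by the values given here, a single step is thin evidence, and no measured compound carries trifluoromethoxy. No shift beyond the scatter is therefore expected in this assay, in either direction, with compound 2 at 13300 nM as the anchor.

The estimated change is a 1.2-fold lower number from compound 2 to compound 3 (0.08 log units; within the scatter). For compound 3 the expected value is 11000 nM, with an estimated range from 4500 nM to 24000 nM.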

Compound 3, half-maximal inhibitory concentration: 20200 nM
For compound 3 the middle estimate is 1.8-fold (0.26 log units) below the measured one; low and high end bracket the measured number.
By their numbers in this assay, from the lowest: compounds 1, 2 and 3 (each within the scatter of the next, the first and the last beyond it).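

In this assay, trifluoromethoxy in place of trifluoromethyl on this aromatic carbon gives a 1.5-fold higher number from compound 2 to compound 3 (0.18 log units; within the scatter), so the two groups cannot be told apart at this position, and the added oxygen has no effect that can be read. The position is not entirely insensitive, however: trifluoromethoxy in place of the group of sulfur and fluorine gives a 2.5-fold higher number from compound 1 to compound 3 (0.40 log units; beyond the scatter), a modest step and the only one among these three compounds that lies beyond the scatter, while compound 2 stays within the scatter of both neighbours. No measurement is available that could explain this difference.

Going by these compounds, all three groups at this position carry fluorine and none holds a ring, so it remains open how an amine, a carboxylic acid or a longer chain on this aromatic carbon would read in this assay. Also open, on these data alone, is whether the same small spread would hold with a different group in place of the one on the other aromatic ring, which is the same in all three compounds.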